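A Fluorophenyl in Place of the Methoxyphenyl

This account rests on a few compounds, and the source may have more. Where it says the series, first, only, none or still open, it means among the compounds named here.

Among the three measured compounds, compound 3 `COc1ccc(C2(NC(=O)c3c(OC)cc(C(F)(F)F)cc3SC)CCCN(C)C2)cc1` stands highest in an assay on cells for inhibition of sodium- and chloride-dependent glycine transporter 1 (Homo sapiens) (on this read-out higher numbers stand for an effect only at larger amounts of compound and lower numbers for an effect already at smaller amounts), with 170 nM. Compound 4 `COc1cc(C(F)(F)F)cc(SC)c1C(=O)NC1(c2cccc(F)c2)CCCN(C)C1` differs from it by 3-fluorophenyl in place of 4-methoxyphenyl on a saturated ring carbon. Among the compounds with values here, two measured steps bear on this change: a 7.1-fold higher number from compound 1 to compound 3 (0.85 log units; beyond the scatter) and a 6.1-fold higher number from compound 2 to compound 3 (0.78 log units; beyond the scatter). Compound 1 `COc1cc(C(F)(F)F)cc(SC)c1C(=O)NC1(c2ccccc2)CCCN(C)C1` gives 24 nM and compound 2 `COc1cc(C(F)(F)F)cc(SC)c1C(=O)NC1(c2ccc(Cl)cc2)CCCN(C)C1` gives 28 nM, values within the scatter of each other. In both steps a methoxy group with one hydrogen-bond acceptor enters and the number rises beyond the scatter. Since the 3-fluorophenyl, like the unsubstituted and chloro-bearing rings, carries no hydrogen-bond acceptor, a step of a 5.7-fold lower number from compound 3 to compound 4 (0.75 log units; beyond the scatter) is expected. Compound 4 is therefore estimated at 30 nM, within 12 nM to 80 nM.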

Compound 4, half-maximal effective concentration: 48 nM
Compound 4: middle estimate off by 1.6-fold (0.20 log units), on the low side; the measured number falls inside the stated range.
By their numbers in this assay, from the lowest: compounds 1, 2 and 4 (each within the scatter of the next); then compound 3.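

In this assay, moving from the 4-methoxyphenyl to the 3-fluorophenyl gives a 3.5-fold lower number from compound 3 to compound 4 (0.55 log units; beyond the scatter), so a fluorine-bearing ring at this saturated ring carbon also avoids the high number of compound 3. Against the other rings the change stays small: a 1.7-fold higher number from compound 2 to compound 4 (0.23 log units; within the scatter) and a 2.0-fold higher number from compound 1 to compound 4 (0.30 log units; within the scatter). Among these four compounds only compound 3 stands apart, and the rings of compound 1, compound 2 and compound 4 are not told apart by this read-out. Nothing shown explains why the methoxy-bearing ring stands apart. Going by these compounds, what a 3-methoxyphenyl or a phenyl bearing a nitrile would give at this carbon stays open.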